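Chloro Replacing Hydrogen on the Aryl Ring of a Cyclopropanecarboxamide

The compounds below may be only part of what the source reports. "The series", "measured", "known", "first", "only" and "open" are said of these compounds alone.

Measured compounds:
compound 1, `Cc1c(-c2ccccc2)nsc1NC(=O)[C@@H]1C[C@H]1C`: > 12500 nM
compound 2, `COc1ccc(-c2nsc(NC(=O)[C@@H]3C[C@H]3C)c2C)cc1F`: 159 nM

In a functional assay for antagonist activity at metabotropic glutamate receptor 5 (Homo sapiens) (on this read-out higher numbers stand for weaker inhibition and lower numbers for stronger inhibition), compound 1 gives > 12500 nM, which is a limit of the assay rather than a measured number (the limit of > 12500 nM in this assay, at which 1 of the 2 values shown sits). In this assay compound 2 gives 159 nM. Compound 1 therefore stands at the weak end of what has been measured, and compound 2 sits well inside the measurable range.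

Compound 3, `Cc1c(-c2ccc(Cl)cc2)nsc1NC(=O)[C@@H]1C[C@H]1C`, differs from compound 1 by chloro in place of hydrogen on an aromatic carbon. Among the measured compounds shown here, no measured pair isolates this change, so the step in this assay can only be judged from the two values shown. Compound 3 is expected to move toward stronger inhibition than compound 1, with a step of an at least 8.3-fold lower number from compound 1 to compound 3 (0.92 log units; beyond the scatter) in this assay. Compound 3 is estimated at 1500 nM, expected to lie between 300 nM and 12500 nM.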

Compound 3, half-maximal inhibitory concentration: 1220 nM
Compound 3: the middle estimate sits 1.2-fold (0.09 log units) above what was measured, within the range that was stated.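

In this assay chloro in place of hydrogen gives an at least 10-fold lower number from compound 1 to compound 3 (1.01 log units; beyond the scatter) and so brings the unsubstituted aryl compound into the measurable range. Among the compounds shown here, this is the first one-place comparison here, and it shows that this aromatic carbon, para to a large group, responds strongly to a single chlorine atom. The step is only a bound, since compound 1 carries a limit of the assay and not a number: the limit of > 12500 nM in this assay, at which 1 of the 3 values shown sits.

The compounds shown leave open whether this gain is particular to chloro or would also come with bromo, trifluoromethyl or an amine on the same carbon. As far as these compounds go, whether chloro on another carbon of the ring would give a step of similar size also remains open.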